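The source may report more compounds than this note shows. Statements on the series, on what has been measured and on what is new or still open speak of the compounds shown alone.

Measured so far:
- compound 1 `O=c1cc(N2CCN(CC3CCC(OS(=O)(=O)c4cccnc4)CC3)CC2)sc2c([N+](=O)[O-])cc(C(F)(F)F)cc12`: in an ADME assay on Vero cells (Chlorocebus sabaeus) for cytotoxicity, read by MTT assay, with a stated time of 48 h (on this read-out lower numbers stand for stronger inhibition and higher numbers for weaker inhibition), compound 1 gives > 64 ug/mL, a limit of the assay and not a number.
- compound 2 `CC(=O)OC1CCC(CN2CCN(c3cc(=O)c4cc(C(F)(F)F)cc([N+](=O)[O-])c4s3)CC2)CC1`: in this assay compound 2 gives > 64 ug/mL, likewise a limit of the assay.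

Compound 2 thus stands at the limit of > 64 ug/mL in this assay, at which 2 of the 2 values shown sit. Among the compounds with values here, the only measured step, a step that the two limits leave unreadable from compound 1 to compound 2, cannot be read. Compound 3 `COc1ccc(C(=O)OC2CCC(CN3CCN(c4cc(=O)c5cc(C(F)(F)F)cc([N+](=O)[O-])c5s4)CC3)CC2)cc1` differs from compound 2 by 4-methoxyphenyl in place of methyl on a carbonyl carbon. Within the data shown here, no measured step bears on this change, so no direction can be drawn from the series. Compound 3 is expected to remain at the same limit, the step that the limit leaves unreadable from compound 2 to compound 3 being expected to show nothing beyond the scatter. For compound 3 in this assay the estimate is 80 ug/mL, ranging from 32 ug/mL to 200 ug/mL.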

Compound 3, half-maximal inhibitory concentration: > 64 ug/mL
Compound 3 was reported as a limit (the forecaster's own chance of this, stated with the estimate: 75%); the middle value does not contradict the limit.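

No new step can be read among compound 1, compound 2 and compound 3, as each value in this assay is a limit of the assay and not a number: the limit of > 64 ug/mL in this assay, at which 3 of the 3 values shown sit.

The compounds shown leave open whether acetyl, (4-methoxyphenyl)carbonyl or (pyridin-3-yl)sulfonyl on that oxygen makes any difference to the read-out.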